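This account rests on a few compounds, and the source may have more. Where it says the series, first, only, none or still open, it means among the compounds named here.

Compound 1 `N#Cc1cnc(NCc2ccccc2C(F)(F)F)cc1N[C@H]1CC[C@@H](O)CC1` and compound 2 `N#Cc1cnc(NCc2cnccc2C(F)(F)F)cc1NC[C@H]1CC[C@@H](O)CC1` have been measured in an ADME assay on S9 fraction from liver (Homo sapiens) for metabolic stability, with a stated time of 1 h; on this read-out lower numbers stand for a less stable compound and higher numbers for a more stable compound. In this assay compound 1 gives 0%, the lowest of the two numbers, and compound 2 gives 41%, a gap that lies beyond the usual scatter. Compound 3 `N#Cc1cnc(NCc2ccccc2C(F)(F)F)cc1N[C@H]1CC[C@@H](C(N)=O)CC1` differs from compound 1 in one place: carbamoyl in place of hydroxy on a saturated ring carbon. Within the data shown here, no measured pair shows this change, so its effect is open. Because compound 1 sits at 0%, the lowest of the two measured numbers, a small rise is expected, a number 15 percentage points higher from compound 1 to compound 3 (beyond the scatter). Compound 3 is therefore estimated at 15%, with a range from 0% to 45%.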

Compound 3, percent of the compound remaining: 48%
The estimate for compound 3 lay 33 percentage points below the measured number; measured number outside the range, above it.
By their numbers in this assay, from the lowest: compound 1; then compounds 2 and 3 (each within the scatter of the next).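

In this assay, carbamoyl in place of hydroxy on this saturated ring carbon gives a number 48 percentage points higher from compound 1 to compound 3 (beyond the scatter), with the rest of the molecule unchanged. This single pair shows that the group at this position alone can shift the number by a large amount. Nothing available explains the shift.

On these data alone, whether an amine or a carboxylic acid at this position would behave like carbamoyl remains open. So does whether the same change would give a similar step on another core, as a single pair cannot show a general pattern.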